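Working notes: 1-acetylpiperidin-4-yl to 1-methylpiperidin-4-yl

This account rests on a few compounds, and the source may have more. Where it says the series, first, only, none or still open, it means among the compounds named here.

Values in a physicochemical assay for solubility, in phosphate buffer, with a stated time of 24 h, at pH 7.4, tested at 100 uM (on this read-out lower numbers stand for lower solubility and higher numbers for higher solubility), so far:
- compound 1 `CC(C)n1cc(S(=O)(=O)c2ccc(CNC(=O)N3Cc4ccncc4C3)cc2)cn1` gives 192000 nM
- compound 2 `CC(=O)N1CCC(S(=O)(=O)c2ccc(CNC(=O)N3Cc4ccncc4C3)cc2)CC1` gives 187000 nM

Compound 2 stands level with compound 1 on these numbers, the two values lying within the scatter of each other. The next compound, compound 3 `CN1CCC(S(=O)(=O)c2ccc(CNC(=O)N3Cc4ccncc4C3)cc2)CC1`, has methyl in place of acetyl on an amine nitrogen in a ring, and the counted difference from compound 2 is methyl in place of acetyl on an amine nitrogen in a ring. Among the compounds with values here, only one measured step is available, a 1.0-fold lower number from compound 1 to compound 2 (0.01 log units; within the scatter), and it concerns a group on a sulfonyl sulfur. Within the data shown here, no measured step covers a change on the amine nitrogen itself, so the evidence is indirect. No step beyond the scatter is therefore expected in this assay. The estimated step is a 1.0-fold higher number from compound 2 to compound 3 (0.01 log units; within the scatter) and would stay small. For compound 3 the expected value is 190000 nM, with an estimated range of 125000 nM to 240000 nM as its likely span.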

Compound 3, solubility: 240000 nM
Estimate against measurement, compound 3: 1.3-fold (0.10 log units) below; the measured number falls inside the stated range.
By their numbers in this assay, from the lowest: compounds 2, 1 and 3 (each within the scatter of the next).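

In this assay, the series now holds a measured change on the amine nitrogen in the six-membered non-aromatic ring: methyl in place of acetyl, with 3 heavy atoms leaving, 1 entering and the hydrogen-bond acceptor gone, gives a step (a 1.3-fold higher number from compound 2 to compound 3 (0.11 log units; within the scatter)) that stays within the scatter. The 1-methylpiperidin-4-yl group on the sulfonyl sulfur also stands level with 1-isopropyl-1H-pyrazol-4-yl (a 1.3-fold higher number from compound 1 to compound 3 (0.10 log units; within the scatter)), so all three groups shown at this sulfur lie within the scatter of one another on this read-out. No other measurement bears on this result.

Going by these compounds, whether a longer chain or a carboxylic acid on the same ring nitrogen would give a step beyond the scatter remains open. Changes elsewhere on the shared core also remain open.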